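Triazole amides with a para substituent swap

The compounds below may be only part of what the source reports. "The series", "measured", "known", "first", "only" and "open" are said of these compounds alone.

Three triazole-linked amides were measured in a functional assay on MIA PaCa-2 cells (Homo sapiens) for antiproliferative activity, read by sulforhodamine B assay, with a stated time of 48 h; on this read-out higher numbers stand for weaker inhibition of growth and lower numbers for stronger inhibition of growth. Compound 1 `O=C(NCc1cn(Cc2ccc(C(F)(F)F)cc2)nn1)c1cn(-c2ccccc2)nc1-c1ccc(F)cc1` gives 760 nM. Compound 2 `COc1ccc(Cn2cc(CNC(=O)c3cn(-c4ccccc4)nc3-c3ccc(F)cc3)nn2)cc1` gives 3700 nM, differing from compound 1 by methoxy in place of trifluoromethyl on an aromatic carbon, a change that made a 4.9-fold higher number from compound 1 to compound 2 (0.69 log units; beyond the scatter). Compound 3 `O=C(NCc1cn(Cc2ccc(C(F)(F)F)cc2)nn1)c1cn(-c2ccccc2)nc1-c1ccc(Cl)cc1` gives 1100 nM; it differs from compound 1 by chloro in place of fluoro on an aromatic carbon, and the step was a 1.4-fold higher number from compound 1 to compound 3 (0.16 log units; within the scatter), so these two values cannot be ordered. Against compound 2, compound 3 stands with the lower number of the pair, a gap beyond the scatter.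

Compound 4 `COc1ccc(Cn2cc(CNC(=O)c3cn(-c4ccccc4)nc3-c3ccc(Cl)cc3)nn2)cc1` has not yet been measured. It differs from compound 3 by methoxy in place of trifluoromethyl on an aromatic carbon. This is the same change that led from compound 1 to compound 2, and here it is made on the core of compound 3 rather than the core of compound 1, the two cores being set apart by chloro in place of fluoro on an aromatic carbon. Among the four compounds the change occurs twice in all, and only one instance carries a measurement, so the expectation rests on a single pair. That pair gave a 4.9-fold higher number from compound 1 to compound 2 (0.69 log units; beyond the scatter). For compound 4 the expected step in this assay is a 4.5-fold higher number from compound 3 to compound 4 (0.66 log units; beyond the scatter), because the same change gave a 4.9-fold higher number from compound 1 to compound 2 (0.69 log units; beyond the scatter) and the cores are close in value. Compound 4 is estimated to give 5000 nM, with a range expected from 2200 nM to 12000 nM.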

Compound 4, concentration for 50% growth inhibition: 290 nM
Beside the measured number, compound 4's estimate is 17-fold (1.24 log units) above it; measured number outside the range, below it.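

Carrying methoxy in place of trifluoromethyl from one core to the other did not preserve the direction of the step: on the core of compound 3 in this assay it gave a 3.8-fold lower number from compound 3 to compound 4 (0.58 log units; beyond the scatter), and the comparison with the core of compound 1 reads: the same change on two cores in this assay, a 4.9-fold higher number (0.69 log units; beyond the scatter) from compound 1 to compound 2 and a 3.8-fold lower number (0.58 log units; beyond the scatter) from compound 3 to compound 4, 18-fold (1.27 log units) apart, beyond the scatter of two such steps. Seen from the other place, chloro in place of fluoro gave a 13-fold lower number from compound 2 to compound 4 (1.11 log units; beyond the scatter) with methoxy on the benzyl group, and the comparison with the same swap alongside trifluoromethyl reads: the same change on two cores in this assay, a 1.4-fold higher number (0.16 log units; within the scatter) from compound 1 to compound 3 and a 13-fold lower number (1.11 log units; beyond the scatter) from compound 2 to compound 4, 18-fold (1.27 log units) apart, beyond the scatter of two such steps. These four compounds therefore show that the two changes do not simply add up in this series, so a step measured on one of these cores is a poor guide to the other, but they do not show why the sign turns over or whether the same reversal extends to any compound beyond these four.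

The compounds shown leave open whether the turn depends on methoxy itself or would also appear with another group in that place, such as a nitrile, a dimethylamino group or a hydroxyl. They also leave open how bromo or methyl in place of chloro on the other aryl ring would behave with either 4-methoxybenzyl or 4-(trifluoromethyl)benzyl.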